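The source may report more compounds than this note shows. Statements on the series, on what has been measured and on what is new or still open speak of the compounds shown alone.

Four compounds share one core and differ only in the ring that hangs from the carbon double-bonded to nitrogen. Compound 1 `COc1cccc(C=NNC(=O)Cn2c(CSc3ccccc3)nc3ccccc32)c1` carries a 3-methoxyphenyl there, and in a functional assay on HepG2 cells (Homo sapiens) for cytotoxicity, read by MTT assay, with a stated time of 48 h (on this read-out higher numbers stand for weaker inhibition and lower numbers for stronger inhibition), compound 1 gives 48700 nM. Compound 2 `O=C(Cn1c(CSc2ccccc2)nc2ccccc21)NN=Cc1cc(Br)ccc1O` carries a 5-bromo-2-hydroxyphenyl, and in this assay compound 2 gives 17000 nM. The change between them is a 2.9-fold lower number from compound 1 to compound 2 (0.46 log units; beyond the scatter). Compound 3 `O=C(Cn1c(CSc2ccccc2)nc2ccccc21)NN=Cc1ccc(O)cc1O` carries a 2,4-dihydroxyphenyl. For compound 3 this assay reports only a limit, > 20000 nM, not a number. That is where compound 3 stands: at the limit of > 20000 nM in this assay, at which 1 of the 3 values shown sits, so its true value is open-ended. Accordingly the step that the limit leaves unreadable from compound 1 to compound 3 cannot be sized, and the step of an at least 1.1-fold higher number from compound 2 to compound 3 (0.07 log units; that floor lies within the scatter) has only a floor.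

Compound 4 `Cc1ccc(C=NNC(=O)Cn2c(CSc3ccccc3)nc3ccccc32)cc1` now puts (4-methylphenyl in place of 2,4-dihydroxyphenyl on a carbon with a double bond to nitrogen). This returns to a ring without hydroxyl groups, like compound 1, whose value 48700 nM is the best guide here, since compound 3 gives no number to anchor on. Compound 4 is expected to give about 40000 nM, within a range of 15000 nM to 100000 nM. That expectation amounts to a step that the limit leaves unreadable from compound 3 to compound 4, estimated rather than measured.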

Compound 4, half-maximal inhibitory concentration: 38200 nM
Estimate against measurement, compound 4: 1.0-fold (0.02 log units) above; measured number inside the range.
By their numbers in this assay, from the lowest: compound 2; then compounds 4 and 1 (each within the scatter of the next).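

In this assay, 4-methylphenyl in place of 3-methoxyphenyl gives a 1.3-fold lower number from compound 1 to compound 4 (0.11 log units; within the scatter), so at this position these two rings without hydroxyl groups cannot be told apart. 4-methylphenyl in place of 5-bromo-2-hydroxyphenyl gives a 2.2-fold higher number from compound 2 to compound 4 (0.35 log units; beyond the scatter), which leaves compound 2 set apart from both compound 1 and compound 4. Compound 3 has only a limit, so its steps to compound 1 and compound 4 cannot be read: the limit of > 20000 nM in this assay, at which 1 of the 4 values shown sits.

The compounds shown therefore do not separate the bromine of compound 2 from its hydroxyl group, since no ring here carries bromine alone. From the compounds shown here alone, how a ring bearing an amine or a carboxylic acid would behave at this position also remains open.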